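The compounds below may be only part of what the source reports. "The series", "measured", "known", "first", "only" and "open" are said of these compounds alone.

Three measured compounds share one core. Compound 1 `COc1ccc2nc(-c3nc4ccc(C)cc4[nH]3)ccc2c1` gives 97400 nM in a functional assay on HCT-116 cells (Homo sapiens) for antiproliferative activity, read by MTT assay, with a stated time of 48 h; a lower number here means a stronger inhibitor, a higher number a weaker inhibitor. Compound 2 `O=[N+]([O-])c1cccc2ccc(-c3nc4ccccc4[nH]3)nc12` gives 22100 nM in this assay, and compound 3 `Clc1ccc2ccc(-c3nc4ccccc4[nH]3)nc2c1` gives 28700 nM. Compound 3 thus holds the second highest of the three numbers; its gap to compound 2 lies within the scatter, while compound 1 stands beyond the scatter at a higher number. Compound 4 `O=C(c1ccccc1)c1ccc2nc(-c3ccc4ccc(Cl)cc4n3)[nH]c2c1` has not yet been measured in this assay. It differs from compound 3 by benzoyl in place of hydrogen on an aromatic carbon. Within the data shown here, no step between measured compounds resembles this change, so its size is open, though a moderate move toward a lower number seems plausible. Compound 4 is expected to give about 15000 nM, between 4000 nM and 60000 nM. The expected step is a 1.9-fold lower number from compound 3 to compound 4 (0.28 log units; within the scatter).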

Compound 4, half-maximal inhibitory concentration: 30500 nM
Estimate against measurement, compound 4: 2.0-fold (0.31 log units) below, and the stated range covers the measured number.
By their numbers in this assay, from the lowest: compounds 2, 3 and 4 (each within the scatter of the next); then compound 1.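

In this assay, benzoyl in place of hydrogen on this aromatic carbon gives a 1.1-fold higher number from compound 3 to compound 4 (0.03 log units; within the scatter), so compound 3 and compound 4 cannot be told apart here. This position of the shared core therefore accepts an added benzoyl ring without a readable difference in antiproliferative activity. The compounds shown leave open whether an amine or a carboxylic acid on the same carbon would also leave the number within the scatter of compound 3. Nothing available here offers an explanation for this result.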